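The compounds below may be only part of what the source reports. "The series", "measured", "known", "first", "only" and "open" are said of these compounds alone.

Measured compounds:
- compound 1, `CCCN1CCCN(c2nc3ccccc3n2CCOCC)CC1`, 8.4 nM
- compound 2, `CCCOCCn1c(N2CCN(C)CC2)nc2ccccc21`, 20 nM
- compound 3, `CCCCCN1CCN(c2nc3ccccc3n2CCOCC)CC1`, 30 nM

All three were tested in a functional assay on ileum for inhibition of histamine H1 receptor (Cavia porcellus); on this read-out lower numbers stand for stronger inhibition and higher numbers for weaker inhibition. Compound 2, with 20 nM, gives the second highest of the three numbers. Its nearest neighbour is compound 3, whose 30 nM lies within the usual scatter of this assay, so the two cannot be told apart. Compound 1 stands furthest away, and its 8.4 nM marks a difference that goes beyond the scatter, so compound 1 inhibits more strongly than compound 2 on these numbers.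

The step under consideration leads from compound 2 to the not yet measured compound 4, `CCCCOCCn1c(N2CCN(C)CC2)nc2ccccc21`. The change is small: methyl in place of hydrogen on a saturated chain carbon, three bonds along the chain from an oxygen on a saturated carbon. Nothing else in the molecule moves. For the measured compounds named here, no step between any two measured compounds here isolates this kind of change, so there is no measured precedent to lean on. A single added carbon on a chain of this sort is expected to leave the number in this assay roughly where it is, with no step beyond the scatter in either direction; the expected step is a 1.3-fold higher number from compound 2 to compound 4 (0.10 log units; within the scatter). Compound 4 is therefore estimated at 25 nM, with a range from 8 nM to 75 nM.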

Compound 4, half-maximal inhibitory concentration: 38 nM
Estimate against measurement, compound 4: 1.5-fold (0.18 log units) below; low and high end bracket the measured number.
By their numbers in this assay, from the lowest: compound 1; then compounds 2, 3 and 4 (each within the scatter of the next).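

In this assay, replacing hydrogen with methyl on a saturated chain carbon, three bonds along the chain from an oxygen on a saturated carbon, gives a 1.9-fold higher number from compound 2 to compound 4 (0.28 log units; within the scatter), and this step lies within the scatter. This pair supplies the first direct comparison among the compounds shown, since it differs in one place only, and it shows that going from propyl to butyl here produces no difference that the assay can separate from the variation between repeated measurements. No accompanying data bear on this result, so the numbers alone offer no explanation for it.

For the compounds shown here, the step covers only one position and one change, so it remains open whether a longer chain such as pentyl, a branched chain such as isopropyl, or a hydroxyl group at the chain end would also stay within the scatter. Compounds 1 and 3 differ from compound 2 in more than one place, which leaves open whether the same methyl change would give a similar step on those other structures.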